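Phenyl Replaces Pyrazin-2-yl on a Ring Amine Nitrogen

The source may report more compounds than this note shows. Statements on the series, on what has been measured and on what is new or still open speak of the compounds shown alone.

Compound 1 `Nc1ccccc1NC(=O)c1ccc(CSC(=S)N2CCN(c3cccnc3)CC2)cc1` and compound 2 `Nc1ccccc1NC(=O)c1ccc(CSC(=S)N2CCN(c3cnccn3)CC2)cc1` share one core. In a functional assay on MGC-803 cells (Homo sapiens) for antiproliferative activity, read by CCK-8 assay, with a stated time of 72 h, tested at 2 uM (a higher number here means a stronger effect of the compound at the concentration tested, a lower number a weaker effect), compound 1 gives 27.6% and compound 2 gives 27.1%, the lower of the two numbers yet within the scatter of compound 1, as the step of a number 0.5 percentage points lower from compound 1 to compound 2 (within the scatter) shows. Compound 3 `Nc1ccccc1NC(=O)c1ccc(CSC(=S)N2CCN(c3ccccc3)CC2)cc1` differs from compound 2 by phenyl in place of pyrazin-2-yl on an amine nitrogen in a ring. Within the data shown here, no measured step matches this exchange; the only one, a number 0.5 percentage points lower from compound 1 to compound 2 (within the scatter), swapped one six-membered aromatic ring bearing hetero atoms for another and stayed within the scatter, so nothing beyond the scatter is expected in this assay. Compound 3 is therefore expected to give about 26%, between 15% and 37%. The step of a number 1.1 percentage points lower from compound 2 to compound 3 (within the scatter) is expected to remain within the scatter.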

Compound 3, a percentage reported as inhibition, at one concentration (the size of the read-out at that concentration, not a potency): 42.3%
Beside the measured number, compound 3's estimate is 16.3 percentage points below it; the measured number lies above the stated range.
By their numbers in this assay, from the lowest: compounds 2 and 1 (each within the scatter of the next); then compound 3.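

With phenyl on the amine nitrogen in the ring, this assay gives a number 15.2 percentage points higher from compound 2 to compound 3 (beyond the scatter) and also a number 14.7 percentage points higher from compound 1 to compound 3 (beyond the scatter) while the exchange between the two rings with hetero atoms stayed within the scatter. The read-out at this position thus separates the ring of carbon only from both rings bearing nitrogen, though it does not separate those two from each other. Nothing at hand gives a reason for this rise. On these data alone, whether a phenyl ring carrying a methoxy group or a chlorine keeps this gain remains open, as does the effect of a benzyl group on the same nitrogen.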